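From 3-methylphenyl to 4-methylphenyl on a shared core

The compounds below may be only part of what the source reports. "The series", "measured", "known", "first", "only" and "open" are said of these compounds alone.

In a functional assay on PC-3 cells (Homo sapiens) for cytotoxicity, read by sulforhodamine B assay, with a stated time of 48 h (a lower number here means a stronger inhibitor, a higher number a weaker inhibitor), compound 1 `C[C@H]1CC[C@@H]2[C@@H](OC(=O)[C@]23CC(c2ccc(O)cc2)=NO3)[C@]2(C)C(=O)C=C[C@@]12O` gives 20000 nM, compound 2 `C[C@H]1CC[C@@H]2[C@@H](OC(=O)[C@]23CC(c2cccc([N+](=O)[O-])c2)=NO3)[C@]2(C)C(=O)C=C[C@@]12O` gives 55000 nM and compound 3 `Cc1cccc(C2=NO[C@]3(C2)C(=O)O[C@@H]2[C@H]3CC[C@H](C)[C@]3(O)C=CC(=O)[C@@]23C)c1` gives 66600 nM. Compound 3 thus stands level with compound 2, at a 1.2-fold higher number from compound 2 to compound 3 (0.08 log units; within the scatter), and clear of compound 1, at a 3.3-fold higher number from compound 1 to compound 3 (0.52 log units; beyond the scatter). Compound 4 `Cc1ccc(C2=NO[C@]3(C2)C(=O)O[C@@H]2[C@H]3CC[C@H](C)[C@]3(O)C=CC(=O)[C@@]23C)cc1` differs from compound 3 as follows: 4-methylphenyl in place of 3-methylphenyl on a carbon with a double bond to nitrogen. Within the data shown here, no measured step shows a methyl changing place. The closest evidence is the nitro-to-methyl swap, a 1.2-fold higher number from compound 2 to compound 3 (0.08 log units; within the scatter), while the larger replacement of 4-hydroxyphenyl gave a 2.8-fold higher number from compound 1 to compound 2 (0.44 log units; beyond the scatter). A change beyond the scatter is therefore not expected, and the estimated step is a 1.1-fold lower number from compound 3 to compound 4 (0.05 log units; within the scatter). Compound 4 is expected at about 60000 nM, within an estimated range of 30000 nM to 110000 nM.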

Compound 4, half-maximal inhibitory concentration: 14000 nM
For compound 4 the middle estimate is 4.3-fold (0.63 log units) above the measured one; measured number below the stated range.
By their numbers in this assay, from the lowest: compounds 4 and 1 (each within the scatter of the next); then compounds 2 and 3 (each within the scatter of the next).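

In this assay, among these compounds, moving the methyl from 3-methylphenyl to 4-methylphenyl is itself a step beyond the scatter (a 4.8-fold lower number from compound 3 to compound 4 (0.68 log units; beyond the scatter)), so at this position the place of the methyl on the aromatic ring counts, which the earlier compounds could not show. Replacing 3-nitrophenyl gives a similar step (a 3.9-fold lower number from compound 2 to compound 4 (0.59 log units; beyond the scatter)), while methyl in place of hydroxy stays within the scatter (a 1.4-fold lower number from compound 1 to compound 4 (0.15 log units; within the scatter)). Nothing available here accounts for these differences. The compounds shown leave open whether an amine or a carboxylic acid on the aromatic ring would track the methyl or the hydroxy, and whether the place of other groups on that ring counts equally.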